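A few compounds are considered here, and "the series" means these few. Any claim that something is new, unique, unknown or untested is made for them only; others in the source may bear on it.

Three compounds built on the shared core of compound 1, `COc1cc(O)c(C(=O)/C=C/c2ccc(OC)c(OCc3cn(-c4ccccc4Cl)nn3)c2)c(OC)c1`, have been run in an ADME assay on Huh-7 cells (Homo sapiens) for cytotoxicity, read by MTT assay, with a stated time of 72 h; a lower number here means that less compound is tolerated, a higher number that more compound is tolerated. Compound 1 gives only a limit there, > 100 ug/mL. Compound 2, `COc1cc(O)c(C(=O)/C=C/c2ccc(OCc3cn(-c4ccc(F)cc4Cl)nn3)c(OC)c2)c(OC)c1`, likewise reaches only a limit, > 100 ug/mL. Compound 3, `COc1cc(O)c(C(=O)/C=C/c2ccc(OCc3cn(-c4ccccc4Cl)nn3)c(OC)c2)c(OC)c1`, again returns a limit, > 100 ug/mL. Among the measured compounds shown here, the one step that can be traced, a step that the two limits leave unreadable from compound 2 to compound 3, is unreadable: both ends sit at the limit of > 100 ug/mL in this assay, at which 3 of the 3 values shown sit, so neither a size nor a direction can be drawn from it. Compound 3 thus stands at the limit alongside the other two measured compounds, with no number of its own.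

Compound 4, `COc1cc(O)c(C(=O)/C=C/c2ccc(OCc3cn(-c4ccccc4Cl)nn3)c(OCc3cn(-c4ccccc4Cl)nn3)c2)c(OC)c1`, differs from compound 3 by 1-(2-chlorophenyl)-1H-1,2,3-triazol-4-yl in place of hydrogen on a saturated chain carbon bound to an oxygen on an aromatic ring. For the measured compounds named here, no measured step bears on this change; the only traced step, a step that the two limits leave unreadable from compound 2 to compound 3, concerns a different change and is itself unreadable. Going by the values given here, what the numbers show is simply that every value so far sits at the limit of > 100 ug/mL in this assay, at which 3 of the 3 values shown sit. On that basis compound 4 is expected to remain at or near the same limit in this assay, with the step of a number no higher from compound 3 to compound 4 (the limit leaves the size open) expected to be none beyond the scatter. Compound 4 is therefore estimated at 100 ug/mL, within a range from 50 ug/mL to 200 ug/mL, and the assay is most likely to report only a limit for it.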

Compound 4, half-maximal cytotoxic concentration: > 100 ug/mL
Compound 4 was reported as a limit; the forecaster's own chance of this, stated with the estimate: 80%; the middle value lies on the limit itself.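

Neither step into compound 4, from compound 3 or from compound 1, can be read in this assay, because each pair ends at a limit and not at a number: the limit of > 100 ug/mL in this assay, at which 4 of the 4 values shown sit.

The compounds shown leave open what concentration any of them actually tolerates, and whether adding the 1-(2-chlorophenyl)-1H-1,2,3-triazol-4-yl group changes it at all.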